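The compounds below may be only part of what the source reports. "The series", "measured", "known", "first", "only" and "open" are said of these compounds alone.

Three compounds built on a shared core were tested in a functional assay (strain AB) with Danio rerio as the target, read by microscopy, with a stated time of 1 h; on this read-out lower numbers stand for an effect already at smaller amounts and higher numbers for an effect only at larger amounts of compound. Compound 1 `CCC(O)c1cc2c(cc1NC(=O)Nc1ccc(Cl)cc1)OCCO2` reached only a limit of the assay, > 25000 nM. Compound 2 `NC(=O)c1c(NC(=O)Nc2ccc(Cl)cc2)sc2c1CCN(CC1CCC1)C2` gives 1360 nM, the lowest of the two full numbers shown. Compound 3 `CCN1CCc2c(sc(NC(=O)Nc3ccc(Cl)cc3)c2C(=O)NCCO)C1` gives 9400 nM, a higher number, and the gap between them lies beyond the usual scatter. One of the three values is thus a limit rather than a number (the limit of > 25000 nM in this assay, at which 1 of the 3 values shown sits).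

Compound 4 `CCCN1CCc2c(sc(NC(=O)Nc3ccc(Cl)cc3)c2C(N)=O)C1` differs from compound 2 in one place: ethyl in place of cyclobutyl on a saturated chain carbon bound to an amine nitrogen in a ring. Within the data shown here, no measured pair shows this change on its own, so a small rise in this assay, or none beyond the scatter, is expected. Compound 4 is expected to give about 2500 nM, within a range from 800 nM to 8000 nM. The expected step is a 1.8-fold higher number from compound 2 to compound 4 (0.26 log units; within the scatter).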

Compound 4, half-maximal effective concentration: 3500 nM
Compound 4: middle estimate off by 1.4-fold (0.15 log units), on the low side; the range from low to high includes it.
By their numbers in this assay, from the lowest: compound 2; then compound 4; then compound 3. At a limit, above all of these: compound 1.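

Ethyl in place of cyclobutyl, on a saturated chain carbon bound to an amine nitrogen in a ring, gives a 2.6-fold higher number from compound 2 to compound 4 (0.41 log units; beyond the scatter), the first step here that changes one place only. The number therefore responds to this position, modestly, and compound 4 still gives a full value rather than a limit. Nothing measured here explains the step.

Still open, on these data alone, is how a hydroxyl or an amine on this chain would move the number. As far as these compounds go, whether a cyclohexyl ring would go beyond cyclobutyl also remains open.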